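From methyl to ethyl on the ring amide nitrogen

A few compounds are considered here, and "the series" means these few. Any claim that something is new, unique, unknown or untested is made for them only; others in the source may bear on it.

compound 1 `CN1CCN(c2ccc(Nc3ncc4c(n3)N(C3CCCC3)CC(=O)N4)cc2)CC1`: > 30000 nM (a limit)
compound 2 `CN1CCN(c2ccc(Nc3ncc4c(n3)N(C3CCCC3)CC(=O)N4C)cc2)CC1`: 12400 nM
compound 3 `CC1CCN(c2ccc(Nc3ncc4c(n3)N(C3CCCC3)CC(=O)N4C)cc2)CC1`: "not determined" (no result reported)

In an ADME assay on HEK293 cells (Homo sapiens) for inhibition, read by MTT assay, with a stated time of 48 h (a higher number here means a weaker inhibitor, a lower number a stronger inhibitor), compound 1 reaches only the assay limit, > 30000 nM. Compound 2 gives 12400 nM in this assay, the only single number shown; compound 3 gives "not determined" (no result reported). Compound 2 therefore stands alone as the one measured figure. Compound 4 `CCN1C(=O)CN(C2CCCC2)c2nc(Nc3ccc(N4CCN(C)CC4)cc3)ncc21` differs from compound 2 by methyl in place of hydrogen on a saturated chain carbon bound to an amide-type nitrogen in a ring. For the measured compounds named here, the only measured step, an at least 2.4-fold lower number from compound 1 to compound 2 (0.38 log units; beyond the scatter), concerns another place and is itself cut off by the limit of > 30000 nM in this assay, at which 1 of the 3 values shown sits, so it gives little guidance for the present change. A step within the scatter is expected, a 1.0-fold lower number from compound 2 to compound 4 (0.01 log units; within the scatter). Compound 4 is therefore estimated at 12000 nM, within 5000 nM to 30000 nM.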

Compound 4, half-maximal inhibitory concentration: > 30000 nM
Compound 4 was reported as a limit (the forecaster's own chance of this, stated with the estimate: 25%); at least 2.5-fold (0.39 log units) between middle value and limit.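

On an amide-type nitrogen in a ring, the change from methyl to ethyl reverses the gain that methyl brought in this assay: an at least 2.4-fold lower number from compound 1 to compound 2 (0.38 log units; beyond the scatter), but then an at least 2.4-fold higher number from compound 2 to compound 4 (0.38 log units; beyond the scatter). Compound 4 reaches only a limit, > 30000 nM. Among the compounds shown, only the methyl of compound 2 gives a single number at this position, so the step from compound 1 to compound 4 cannot be read and the full size of the loss stays unknown: the limit of > 30000 nM in this assay, at which 2 of the 4 values shown sit.

As far as these compounds go, it remains open whether a longer chain, or a chain carrying an amine or a carboxylic acid, on this nitrogen would stay at the limit.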